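The compounds below may be only part of what the source reports. "The series", "measured", "known", "first", "only" and "open" are said of these compounds alone.

In a toxicity assay on THP-1 cells (Homo sapiens) for inhibition (a higher number here means that more compound is tolerated, a lower number that less compound is tolerated), compound 1 `Cn1c(-c2ccccc2)cnc1NC(=O)c1ccc(F)cc1` gives only a limit, > 100000 nM. Compound 2 `COc1ccc(-c2cnc(NC(=O)c3cnc[nH]3)n2C)cc1` likewise reaches only a limit in this assay, > 100000 nM. Within the data shown here, compound 2 therefore stands at the limit of > 100000 nM in this assay, at which 2 of the 2 values shown sit, shared with the one other measured compound, so no real number places it. Compound 3 `COc1ccc(-c2cnc(NC(=O)C3CCCC3)n2C)cc1` differs from compound 2 by cyclopentyl in place of 1H-imidazol-5-yl on a carbonyl carbon. Without a measured step to lean on, the expected step is one of no size beyond the scatter, a number no higher from compound 2 to compound 3 (the limit leaves the size open). Compound 3 is thus expected to sit near 100000 nM, somewhere between 40000 nM and 250000 nM, most likely again only as a limit.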

Compound 3, half-maximal cytotoxic concentration: > 100000 nM
Compound 3 was reported as a limit (the forecaster's own chance of this, stated with the estimate: 80%); the middle value sits exactly at the limit.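

In this assay, among these compounds, compound 2 and compound 3 both give only a limit, so no step between them can be read. What the compounds shown leave open is whether cyclopentyl in place of 1H-imidazol-5-yl changes tolerated concentration at all.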